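The compounds below may be only part of what the source reports. "The series", "measured", "known", "first", "only" and "open" are said of these compounds alone.

Compound 3, of structure `CCCCCCCNC[C@@H]1OC[C@H](N)[C@@H]1O`, stands only at a limit in a functional assay on B16-F10 cells (Mus musculus) for antiproliferative activity, read by MTT assay, with a stated time of 72 h; a higher number here means a weaker inhibitor, a lower number a stronger inhibitor: compound 3 gives > 128000 nM, which is a limit of the assay and not a number. Its two neighbours stand in the same place. Compound 1, of structure `CCCCCCCNC[C@@H]1OC[C@H](N)[C@H]1O`, gives in this assay > 128000 nM, a limit of the assay. Compound 2, of structure `CCCCCCCCNC[C@@H]1OC[C@H](N)[C@H]1O`, gives in this assay > 128000 nM, likewise a limit. The steps among them cannot therefore be sized: a step that the two limits leave unreadable from compound 1 to compound 2 and a step that the two limits leave unreadable from compound 1 to compound 3 remain unreadable because of the limit of > 128000 nM in this assay, at which 3 of the 3 values shown sit, and the second pair is distinguished only by the fact that compounds 1 and 3 differ only in the configuration as drawn.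

Compound 4, of structure `CCCCCCCCCCCNC[C@@H]1OC[C@H](N)[C@@H]1O`, differs from compound 3 by butyl in place of hydrogen on a saturated chain carbon, seven bonds along the chain from an amine nitrogen. Among the compounds with values here, the step from compound 1 to compound 2 also lengthens the chain, but its size is not readable, so no measured step gives a size for the new one. The account can only expect that the longer chain moves compound 4 into the readable range, with wide uncertainty. Compound 4 is expected in this assay at about 60000 nM, between 15000 nM and 200000 nM. The expected step is an at least 2.1-fold lower number from compound 3 to compound 4 (0.32 log units; beyond the scatter).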

Compound 4, half-maximal inhibitory concentration: 19300 nM
Estimate against measurement, compound 4: 3.1-fold (0.49 log units) above; low and high end bracket the measured number.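

In this assay, butyl in place of hydrogen on a saturated chain carbon, seven bonds along the chain from an amine nitrogen, gives an at least 6.6-fold lower number from compound 3 to compound 4 (0.82 log units; beyond the scatter), beyond the scatter. Within the data shown here, this position therefore responds to a change in chain length, at least for the configuration drawn in compound 3, and compound 4 is the first of the series to give a number rather than a limit. The earlier steps stay unreadable, and their sizes cannot be compared with this one, because of the assay's limit: the limit of > 128000 nM in this assay, at which 3 of the 4 values shown sit.

On these data alone, it remains open whether the same butyl change would have a similar effect on the configuration drawn in compound 1. As far as these compounds go, it is also open whether a still longer chain, or a phenyl group in place of butyl, would lower the number further.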